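The compounds below may be only part of what the source reports. "The series", "measured", "known", "first", "only" and "open" are said of these compounds alone.

Measured compounds and their values:

Compound 1 `Cc1ccnc2nc(-c3cccc(Cl)c3)cc(O)c12` gives 15.9 nM in a functional assay on HCT-116 cells (Homo sapiens) for antiproliferative activity; on this read-out lower numbers stand for stronger inhibition of growth and higher numbers for weaker inhibition of growth.
Compound 2 `Oc1cc(-c2ccc3ccccc3c2)nc2ncccc12` gives 3800 nM in this assay.
Compound 3 `Cc1cc(C)c2c(O)cc(-c3cccc(Cl)c3)nc2n1` gives 170 nM in this assay.

Compound 1 and compound 3 differ by one change, (methyl in place of hydrogen on an aromatic carbon), and that change made a step of an 11-fold higher number from compound 1 to compound 3 (1.03 log units; beyond the scatter). Compound 2 stands apart from compound 1: the difference between the two cores is not broken down here, and the two values simply show compound 2 much weaker.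

Compound 4 `Cc1cnc2nc(-c3ccc4ccccc4c3)cc(O)c2c1` has not yet been measured. It differs from compound 2 by methyl in place of hydrogen on an aromatic carbon, the same kind of change as that from compound 1 to compound 3, though the surroundings are not the same: in compound 3 the methyl sits next to the ring nitrogen and meta to a methyl group, whereas in compound 4 it sits two atoms from the ring nitrogen.

Because an 11-fold higher number from compound 1 to compound 3 (1.03 log units; beyond the scatter) showed the added methyl weakening growth inhibition, compound 4 is expected to show a step of a 1.6-fold higher number from compound 2 to compound 4 (0.20 log units; within the scatter) in this assay, smaller than that earlier step since the place differs. Compound 4 is therefore estimated at 6000 nM, within 2000 nM to 20000 nM.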

Compound 4, concentration for 50% growth inhibition: 468 nM
Beside the measured number, compound 4's estimate is 13-fold (1.11 log units) above it; the whole stated range lies above it.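

In this assay, the methyl gave an 8.1-fold lower number from compound 2 to compound 4 (0.91 log units; beyond the scatter), which means stronger inhibition of growth. Set beside the earlier case, the same change moved the number in opposite directions on the two cores: the same change on two cores in this assay, an 11-fold higher number (1.03 log units; beyond the scatter) from compound 1 to compound 3 and an 8.1-fold lower number (0.91 log units; beyond the scatter) from compound 2 to compound 4, 87-fold (1.94 log units) apart, beyond the scatter of two such steps. A methyl in place of hydrogen on an aromatic carbon therefore does not carry a fixed effect from one core to another in this series, but these two pairs also differ in where the methyl sits and in the rest of the structure, so they do not show which of those differences matters.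

On these data alone, it remains open whether a methyl two atoms from the ring nitrogen would also strengthen growth inhibition on the core of compound 1. As far as these compounds go, it is also open how a longer chain such as ethyl, or a different group such as an amine or methoxy, would behave at that place on the core of compound 2.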